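From Cyanophenyl to Trifluoromethylphenyl: One Expected Step

The compounds below may be only part of what the source reports. "The series", "measured", "known", "first", "only" and "open" are said of these compounds alone.

Of the compounds shown here, three of a shared core have been measured in a functional assay on HepG2 cells (Homo sapiens) for inhibition, read by MTT assay, with a stated time of 72 h; on this read-out higher numbers stand for weaker inhibition and lower numbers for stronger inhibition. Compound 1 `N#Cc1ccc(-n2cc(COc3cccc(NC(=O)Nc4ccc(Cl)c(C(F)(F)F)c4)c3)nn2)cc1` gives 2980 nM. Compound 2 `O=C(Nc1cccc(OCc2cn(-c3cccc(F)c3)nn2)c1)Nc1ccc(Cl)c(C(F)(F)F)c1` gives 2120 nM, and compound 3 `O=C(Nc1cccc(OCc2cn(-c3cccc(I)c3)nn2)c1)Nc1ccc(Cl)c(C(F)(F)F)c1` gives 4780 nM. Among these three numbers compound 1 stands second highest: its nearest neighbour is compound 2, with a 1.4-fold lower number from compound 1 to compound 2 (0.15 log units; within the scatter), and its furthest is compound 3, with a 1.6-fold higher number from compound 1 to compound 3 (0.21 log units; within the scatter). Both of these steps lie within the scatter, whereas the step between the two halogen analogues, a 2.3-fold higher number from compound 2 to compound 3 (0.35 log units; beyond the scatter), is modest but beyond it.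

Compound 4 `O=C(Nc1cccc(OCc2cn(-c3cccc(C(F)(F)F)c3)nn2)c1)Nc1ccc(Cl)c(C(F)(F)F)c1` is not yet measured. It differs from compound 1 by 3-(trifluoromethyl)phenyl in place of 4-cyanophenyl on an aromatic nitrogen. Among the measured compounds shown here, the steps that bear on this change are the two starting from compound 1, in which a 3-fluorophenyl or a 3-iodophenyl group replaced the 4-cyanophenyl group, and both stayed within the scatter. The group entering here, 3-(trifluoromethyl)phenyl, is a third variation at the same aromatic nitrogen, and nothing in the three numbers suggests a move beyond the scatter in this assay.

The estimate for compound 4 is therefore 3000 nM, with a range of 1500 nM to 6500 nM, which means an expected step of a 1.0-fold higher number from compound 1 to compound 4 (0.00 log units; within the scatter).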

Compound 4, half-maximal inhibitory concentration: 1270 nM
Beside the measured number, compound 4's estimate is 2.4-fold (0.37 log units) above it; measured number below the stated range.
By their numbers in this assay, from the lowest: compounds 4, 2, 1 and 3 (each within the scatter of the next, the first and the last beyond it).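

At this aromatic nitrogen, a replacement of the 4-cyanophenyl group can move the result beyond the scatter in this assay: 3-(trifluoromethyl)phenyl gives a 2.3-fold lower number from compound 1 to compound 4 (0.37 log units; beyond the scatter), the only step from compound 1 shown here that does so, and it points toward stronger inhibition. The substituent on the phenyl ring also separates more clearly than before, since trifluoromethyl in place of iodo gives a 3.8-fold lower number from compound 3 to compound 4 (0.58 log units; beyond the scatter), which sets compound 3 apart from compound 4 just as a 2.3-fold higher number from compound 2 to compound 3 (0.35 log units; beyond the scatter) sets it apart from compound 2, while trifluoromethyl in place of fluoro gives a 1.7-fold lower number from compound 2 to compound 4 (0.22 log units; within the scatter), so those two substituents cannot be told apart in this assay. No measurement given here accounts for these differences.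

On these data alone, what an amine or a carboxylic acid on this phenyl ring would do to the number stays open, as does the effect of a longer alkyl chain in place of the phenyl ring on the aromatic nitrogen. The compounds shown also leave open whether the separation of compound 3 from compound 2 and compound 4 would hold outside this assay.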